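A few compounds are considered here, and "the series" means these few. Any claim that something is new, unique, unknown or untested is made for them only; others in the source may bear on it.

Compound 1 `CCOc1ccc2nc(NC(=O)COc3ccc4cc(/C=C5/SC(=O)NC5=O)ccc4c3)sc2c1` gives 17000 nM in an assay on isolated protein for inhibition of histone deacetylase 8 (Homo sapiens), with a stated time of 1 h; a lower number here means a stronger inhibitor, a higher number a weaker inhibitor. Compound 2 `O=C(COc1ccc2cc(/C=C3/SC(=O)NC3=O)ccc2c1)Nc1ccc(F)cc1F` reaches only a limit of the assay, > 50000 nM, in this assay. Compound 3 `O=C(COc1ccc2cc(/C=C3/SC(=O)NC3=O)ccc2c1)Nc1ccccc1` gives 4500 nM in this assay.

Of the two numbers shown, compound 3 has the lowest; the nearest is compound 1, which is higher by a clear margin. Compound 4 `O=C(COc1ccc2cc(/C=C3/SC(=O)NC3=O)ccc2c1)Nc1ccc(F)cc1` is made from compound 3 by a single change: fluoro in place of hydrogen on an aromatic carbon. Among the compounds with values here, one measured step bears on this. Going an at least 11-fold lower number from compound 2 to compound 3 (1.04 log units; beyond the scatter), the removal of both fluorines brought the number down sharply, from a value that sits at the limit of > 50000 nM in this assay, at which 1 of the 3 values shown sits, to a measured number. Adding a single fluorine to compound 3 therefore runs partway back toward compound 2, so a rise in this assay is expected, though smaller than that whole step since only one of the two fluorines returns. The expected step is a 2.0-fold higher number from compound 3 to compound 4 (0.30 log units; within the scatter). For compound 4 the estimate in this assay is 9000 nM, with a range from 3000 nM to 30000 nM.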

Compound 4, half-maximal inhibitory concentration: 6600 nM
Compound 4: middle estimate off by 1.4-fold (0.13 log units), on the high side, within the range that was stated.
By their numbers in this assay, from the lowest: compounds 3 and 4 (each within the scatter of the next); then compound 1. At a limit, above all of these: compound 2.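

In this assay, fluoro in place of hydrogen on the phenyl ring gives a 1.5-fold higher number from compound 3 to compound 4 (0.17 log units; within the scatter), so a single fluorine at this place, para to a large group, brings no change that can be told from the scatter. The sharp gap seen earlier therefore appears only when the second fluorine of the 2,4-difluorophenyl group is also present, as hydrogen in place of that fluoro gives an at least 7.5-fold lower number from compound 2 to compound 4 (0.87 log units; beyond the scatter). Compound 2 is the starting point of that step, and its value is a limit of the assay, not a measured number: the limit of > 50000 nM in this assay, at which 1 of the 4 values shown sits.

A 2-fluorophenyl group would show whether that other fluorine is enough on its own to bring the sharp gap. Going by these compounds, whether a chloro, methyl or methoxy group at the place of the fluoro in the 4-fluorophenyl group would also leave the number unchanged remains open.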